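Swapping cyano for ethoxycarbonyl at the assay limit

The source may hold more compounds than are shown below. What is called first, only, known or untested is meant among the compounds shown, and "the series" means these compounds.

In a functional assay on HCT-116 cells (Homo sapiens) for antiproliferative activity, with a stated time of 48 h (a lower number here means a stronger inhibitor, a higher number a weaker inhibitor), compound 1 `CCN(CC)c1ccc(-c2cccc(OC)c2)nn1` gives > 25000 nM, which is a limit of the assay and not a number. Compound 2 `CCN(CC)c1ccc(-c2cccc(C#N)c2)nn1` gives > 25000 nM, which is likewise a limit. So compound 2 stands with no readable number, and the same is true of the only compound it can be compared with. Compound 3 `CCOC(=O)c1cccc(-c2ccc(N(CC)CC)nn2)c1` follows from compound 2 by a single change: ethoxycarbonyl in place of cyano on an aromatic carbon. Within the data shown here, the one measured step that bears on this is a step that the two limits leave unreadable from compound 1 to compound 2, also a swap on an aromatic carbon, and it offers no size to build on. Since compound 2 sits at the limit of > 25000 nM in this assay, at which 2 of the 2 values shown sit, no step beyond the scatter is expected in this assay, and no direction can be read. The step expected here is a number no higher from compound 2 to compound 3 (the limit leaves the size open). A further limit is the most likely report. For compound 3 the estimated value is 25000 nM, with an expected range from 10000 nM to 50000 nM.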

Compound 3, half-maximal inhibitory concentration: > 25000 nM
Compound 3: no number, only a limit (the forecaster's own chance of this, stated with the estimate: 80%); the middle value sits exactly at the limit.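

Compound 3 also gives only a limit of the assay, so no step linking it to compound 1 or compound 2 can be read: the limit of > 25000 nM in this assay, at which 3 of the 3 values shown sit.

The compounds shown leave open how far compound 1, compound 2 and compound 3 truly differ in this assay, and whether any group in this place gives a readable number.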